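The source may report more compounds than this note shows. Statements on the series, on what has been measured and on what is new or still open speak of the compounds shown alone.

Measured so far:
- compound 1, `c1ccc(Oc2ccc(-c3cc(N4CCNCC4)[nH]n3)cc2)cc1`: 18000 nM
- compound 2, `CCc1ccc(-c2cc(C3CCOCC3)[nH]n2)cc1`: 165000 nM
- compound 3, `CSC(=CC(=O)c1ccc(Oc2ccc([N+](=O)[O-])cc2)cc1)SC`: 156000 nM

These three compounds were tested in an ADME assay on L6 cells (Rattus norvegicus) for cytotoxicity; on this read-out lower numbers stand for stronger inhibition and higher numbers for weaker inhibition. Compound 2 gives the highest number of the three, with 165000 nM. Its nearest neighbour is compound 3, whose 156000 nM lies within the usual scatter of compound 2, so the two cannot be told apart. Compound 1 stands furthest away, and its 18000 nM is a gap beyond the scatter, meaning compound 1 inhibits the cells more strongly than compound 2.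

The next compound, compound 4 `c1ccc(Oc2ccc(-c3cc(C4CCOCC4)[nH]n3)cc2)cc1`, has not yet been measured in this assay. It differs from compound 2 in one place: phenoxy in place of ethyl on an aromatic carbon. Compound 1 also carries a phenoxy group, but it differs from compound 2 in a second place as well, so no single step can be read from that pair; only the two values themselves are known.

With this in mind the change is expected to lower the number somewhat, an estimated step of a 2.8-fold lower number from compound 2 to compound 4 (0.44 log units; beyond the scatter), though the uncertainty is wide. For compound 4 the expected value in this assay is 60000 nM, with a range from 20000 nM to 170000 nM.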

Compound 4, half-maximal inhibitory concentration: 89600 nM
Beside the measured number, compound 4's estimate is 1.5-fold (0.17 log units) below it; the measured number falls inside the stated range.
By their numbers in this assay, from the lowest: compound 1; then compounds 4, 3 and 2 (each within the scatter of the next).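

In this assay, putting phenoxy in place of ethyl on the aromatic carbon gives a 1.8-fold lower number from compound 2 to compound 4 (0.27 log units; within the scatter), so compound 2 and compound 4 cannot be told apart, even though the new group brings a whole extra aromatic ring. At this position, then, a much larger group leaves the read-out within the normal noise of the measurement, at least for this one pair. The other end of the molecule gives a clearer signal: with phenoxy held constant, oxan-4-yl in place of piperazin-1-yl gives a 5.0-fold higher number from compound 1 to compound 4 (0.70 log units; beyond the scatter), a modest step beyond the scatter, which ties the stronger inhibition of compound 1 to the piperazin-1-yl group rather than to phenoxy, although nothing shown here explains either result.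

Still open, from the compounds shown here alone, is whether a quite different group on the same aromatic carbon, such as a carboxylic acid or a longer alkyl chain, would shift the number more clearly. It is also unknown whether another amine, such as an open-chain aminoethyl group, would match piperazin-1-yl in place of oxan-4-yl.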